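Does a methyl amide recover what the propyl ester lost?

The compounds below may be only part of what the source reports. "The series", "measured", "known", "first", "only" and "open" are said of these compounds alone.

Compound 1, `CCc1cccc2c(OC)c(-c3occ(C)c3C(=O)OC)ccc12`, 1.7 ug/mL
Compound 2, `CCCOC(=O)c1c(C)coc1-c1ccc2c(CC)cccc2c1OC`, > 10 ug/mL

In a functional assay on KB cells (Homo sapiens) for cytotoxicity, read by MTT assay, with a stated time of 72 h (a higher number here means that more compound is needed for the effect, a lower number that less compound is needed), compound 1 gives 1.7 ug/mL. Compound 2 gives only a limit in this assay, > 10 ug/mL, so where it truly stands is not known; the same limit is noted as the limit of > 10 ug/mL in this assay, at which 1 of the 2 values shown sits. Going by the values given here, the one measured step, an at least 5.8-fold higher number from compound 1 to compound 2 (0.76 log units; beyond the scatter), shows that lengthening the ester alkyl weakened the effect.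

Compound 3, `CCc1cccc2c(OC)c(-c3occ(C)c3C(=O)NC)ccc12`, differs from compound 2 by methylamino in place of propoxy on a carbonyl carbon. Among the compounds with values here, no measured step covers the change from an ester to an amide; the only nearby step, an at least 5.8-fold higher number from compound 1 to compound 2 (0.76 log units; beyond the scatter), shows that the smaller group on this carbonyl was the more potent one, and the methylamino group is again small. Compound 3 is therefore expected to need less compound than compound 2, with an estimated step of an at least 2.5-fold lower number from compound 2 to compound 3 (0.39 log units; beyond the scatter) in this assay. The estimate for compound 3 is 4 ug/mL, within 1 ug/mL to 20 ug/mL.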

Compound 3, concentration for half-maximal effect: > 10 ug/mL
Compound 3: no number, only a limit (the forecaster's own chance of this, stated with the estimate: 35%); middle value at least 2.5-fold (0.39 log units) from the limit.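

Methylamino in place of methoxy on this carbonyl carbon gives an at least 5.8-fold higher number from compound 1 to compound 3 (0.76 log units; beyond the scatter) in this assay. Methylamino has fewer heavy atoms than propoxy, yet this swap does not return the activity of compound 1, so a small group on the carbonyl carbon is not enough, at least in this one amide. The step between the propyl ester and the methyl amide cannot be read, as both values are limits, and only compound 1 gives a true number: the limit of > 10 ug/mL in this assay, at which 2 of the 3 values shown sit.

On these data alone, how far compound 2 and compound 3 really lie from compound 1 remains open, and so does whether the loss in compound 3 comes with the amide as such or with this particular amide. A dimethylamide or a primary amide on the same carbonyl carbon would help separate those two readings.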